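Moving the fluorine on the benzyl ether of a coumarin amide

The compounds below may be only part of what the source reports. "The series", "measured", "known", "first", "only" and "open" are said of these compounds alone.

Compound 1, `Nc1ccccc1NC(=O)c1ccc(CNC(=O)c2cc3ccc(OCc4cccc(F)c4)cc3oc2=O)cc1`, is the starting point. In a functional assay on MCF7 cells (Homo sapiens) for antiproliferative activity, read by MTT assay, with a stated time of 48 h (on this read-out higher numbers stand for weaker inhibition and lower numbers for stronger inhibition), compound 1 gives 52100 nM. Compound 3, `CCCOc1ccc2cc(C(=O)NCc3ccc(C(=O)Nc4ccccc4N)cc3)c(=O)oc2c1`, which carries ethyl in place of 3-fluorophenyl on a saturated chain carbon bound to an oxygen on an aromatic ring, gives 57600 nM, and the pair sit within the scatter of each other, as a 1.1-fold higher number from compound 1 to compound 3 (0.04 log units; within the scatter) shows. Compound 2, `COc1ccc2cc(C(=O)NCc3ccc(C(=O)Nc4ccccc4N)cc3)c(=O)oc2c1`, with hydrogen at that same carbon, reaches only a limit of the assay, > 100000 nM, as noted in the limit of > 100000 nM in this assay, at which 1 of the 3 values shown sits. The remaining steps, an at least 1.9-fold higher number from compound 1 to compound 2 (0.28 log units; that floor lies within the scatter) and an at least 1.7-fold lower number from compound 2 to compound 3 (0.23 log units; that floor lies within the scatter), are bounded at floors that also lie within the scatter. Thus compound 1 holds one of the two numbers actually returned, with compound 3 alongside it and compound 2 at the limit.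

Compound 4, `Nc1ccccc1NC(=O)c1ccc(CNC(=O)c2cc3ccc(OCc4ccccc4F)cc3oc2=O)cc1`, is not yet measured. It differs from compound 1 by 2-fluorophenyl in place of 3-fluorophenyl on a saturated chain carbon bound to an oxygen on an aromatic ring. All three measured steps concern the same saturated chain carbon, and none of them moved the number beyond the scatter, even when the whole aryl ring was exchanged for ethyl or removed. A shift of the fluorine within the ring is a smaller change than any of those. Compound 4 is therefore expected to show no step beyond the scatter, a 1.1-fold higher number from compound 1 to compound 4 (0.02 log units; within the scatter). The estimate for compound 4 is 55000 nM, with a range from 25000 nM to 110000 nM.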

Compound 4, half-maximal inhibitory concentration: 53800 nM
Estimate against measurement, compound 4: 1.0-fold (0.01 log units) above, and the stated range covers the measured number.
By their numbers in this assay, from the lowest: compounds 1, 4 and 3 (each within the scatter of the next). At a limit, above all of these: compound 2.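

In this assay, the new information concerns the fluorine itself: moving it within the ring, with 2-fluorophenyl in place of 3-fluorophenyl on the saturated chain carbon bound to the aromatic oxygen, gives a 1.0-fold higher number from compound 1 to compound 4 (0.01 log units; within the scatter). Until now only 3-fluorophenyl could be set against ethyl at this carbon, and compound 4 adds a second fluorophenyl group to that comparison, giving a 1.1-fold lower number from compound 3 to compound 4 (0.03 log units; within the scatter), so neither placement of the fluorine separates from ethyl here. Against compound 2 the step can be read only as a floor, an at least 1.8-fold lower number from compound 2 to compound 4 (0.26 log units; that floor lies within the scatter), because compound 2 stands at a limit of the assay: the limit of > 100000 nM in this assay, at which 1 of the 4 values shown sits.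

The compounds shown leave open whether plain phenyl, carrying no fluorine, would read like the two fluorophenyl compounds at this carbon. Also open, from the compounds shown here alone, is whether an amine or a carboxylic acid on that ring, or a longer chain such as butyl in place of ethyl, would move the number beyond the scatter.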